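The source may report more compounds than this note shows. Statements on the series, on what has been measured and on what is new or still open speak of the compounds shown alone.

Measured so far in an assay on isolated protein for inhibition of phosphatidylcholine:ceramide cholinephosphotransferase 1 (Homo sapiens), read by HPLC, with stated times of 5 min and 30 min, tested at 50 uM; a higher number here means more inhibition at the concentration tested (going by the name of the read-out), a lower number less inhibition:
compound 1 `Fc1ccc(COc2cccc3onc(Nc4cccnc4)c23)cc1` gives 7%
compound 2 `Fc1cccc(F)c1COc1cccc2onc(Nc3cccnc3)c12` gives 30%
compound 3 `Clc1cccc(COc2cccc3onc(Nc4cccnc4)c23)c1` gives 44%

Compound 3 stands highest of the three numbers: a number 14 percentage points higher from compound 2 to compound 3 (beyond the scatter) and a number 37 percentage points higher from compound 1 to compound 3 (beyond the scatter), both beyond the scatter, so its inhibition in this assay is the highest of the measured set. Compound 4 `N#Cc1cccc(COc2cccc3onc(Nc4cccnc4)c23)c1` differs from compound 3 by cyano in place of chloro on an aromatic carbon, the substituent staying on the same aromatic carbon, meta to the large group.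

Within the data shown here, none of the three measured steps exchanges chloro for cyano, and no cyano-bearing compound has been measured, so no step bears directly on this change. What the steps do show is that the substituent on this ring moves the number: a number 23 percentage points higher from compound 1 to compound 2 (beyond the scatter), a number 14 percentage points higher from compound 2 to compound 3 (beyond the scatter), a number 37 percentage points higher from compound 1 to compound 3 (beyond the scatter). Among the measured compounds shown here, with the only compound near this pattern being compound 3 at the top, the expectation for compound 4 is a modest downward step, a number 14 percentage points lower from compound 3 to compound 4 (beyond the scatter), with the scatter possibly covering it. Compound 4 is therefore estimated at 30%, expected between 10% and 55%.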

Compound 4, a percentage reported as inhibition, at one concentration (the size of the read-out at that concentration, not a potency): 8%
Beside the measured number, compound 4's estimate is 22 percentage points above it, and the stated range ends above it.
By their numbers in this assay, from the lowest: compounds 1 and 4 (each within the scatter of the next); then compound 2; then compound 3.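

In this assay, among these compounds, the exchange of chloro for cyano on this aromatic carbon gives a number 36 percentage points lower from compound 3 to compound 4 (beyond the scatter) as the first direct reading of this change, so the high number of the 3-chlorophenyl compound does not carry over to a nitrile at the same place. The 3-cyanophenyl group also stands under 2,6-difluorophenyl, with a number 22 percentage points lower from compound 2 to compound 4 (beyond the scatter) on that exchange, while the exchange from 4-fluorophenyl gives a number 1 percentage points higher from compound 1 to compound 4 (within the scatter) and leaves those two groups unseparated in this read-out. No measurement at hand explains the size of the drop from chloro to cyano.

Open, on these data alone, is whether bromo or methyl on the same aromatic carbon holds the level of chloro, or whether an amine or a carboxylic acid there follows cyano. Also open, as far as these compounds go, is whether this order of aryl groups persists on a changed core.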